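Isobutyl Amide in a Series That Has Shown Only Limits

This account rests on a few compounds, and the source may have more. Where it says the series, first, only, none or still open, it means among the compounds named here.

Compound 1, `C=CC1=C(C(=O)O)C(c2ccc(F)cc2)OC1`. In a functional assay on SW480 cells (Homo sapiens) for cytotoxicity, read by MTT assay, with a stated time of 24 h (a higher number here means a weaker inhibitor, a lower number a stronger inhibitor), compound 1 gives > 100000 nM, which is a limit of the assay.
Compound 2, `C=CC1=C(C(=O)Nc2ccccc2OC)C(c2ccc(F)cc2)OC1`. In this assay compound 2 gives > 100000 nM, again a limit.
Compound 3, `C=CC1=C(C(=O)NCc2ccccc2F)C(c2ccc(F)cc2)OC1`. In this assay compound 3 gives > 100000 nM, also a limit.

Compound 3 therefore stands nowhere in particular on the numbers shown: its value is a limit, and so are the two others, since (the limit of > 100000 nM in this assay, at which 3 of the 3 values shown sit). Within the data shown here, the only step between measured compounds that differ in one place, a step that the two limits leave unreadable from compound 2 to compound 3, is unreadable for the same reason.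

Compound 4, `C=CC1=C(C(=O)NCC(C)C)C(c2ccc(F)cc2)OC1`, differs from compound 3 by isopropyl in place of 2-fluorophenyl on a saturated chain carbon bound to an amide-type nitrogen; cut one bond further out, the same change reads 2-fluorobenzyl to isobutyl. Among the measured compounds shown here, no measured step bears readably on this change, and every value shown sits at the limit. For the measured compounds named here, the expectation for the step from compound 3 to compound 4 in this assay is therefore a step that the limit leaves unreadable from compound 3 to compound 4, meaning no step that the assay can read. Compound 4 is estimated at 150000 nM, within 50000 nM to 1000000 nM, most likely reported as a limit again.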

Compound 4, half-maximal inhibitory concentration: > 100000 nM
Compound 4: a limit, no number; the forecaster's own chance of this, stated with the estimate: 85%; the middle value does not contradict the limit.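

In this assay compound 4 gives > 100000 nM, a limit and not a number. Among these compounds, no step from compound 1, compound 2 or compound 3 to compound 4 can be read, because all the values share one limit: the limit of > 100000 nM in this assay, at which 4 of the 4 values shown sit. On these data alone, whether these four compounds differ from one another at all stays open.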